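A Methyl for a Chloro on an Aromatic Ring

The source may hold more compounds than are shown below. What is called first, only, known or untested is meant among the compounds shown, and "the series" means these compounds.

Compound 1 `COc1cc(C(=O)c2sc3ccccc3c2-c2ccccc2)cc(OC)c1OC`: 2100 nM
Compound 2 `COc1cc(C(=O)c2sc3ccccc3c2-c2ccc(F)cc2)cc(OC)c1OC`: 2100 nM
Compound 3 `COc1cc(C(=O)c2sc3ccccc3c2Nc2ccc(Cl)cc2)cc(OC)c1OC`: 1100 nM

All three values come from a functional assay on K562 cells (Homo sapiens) for antiproliferative activity, read by MTT assay, with a stated time of 72 h; on this read-out lower numbers stand for stronger inhibition and higher numbers for weaker inhibition. Compound 3 stands within the scatter of both compound 1 and compound 2, so the numbers do not set it apart from either.

Compound 4 `COc1cc(C(=O)c2sc3ccccc3c2Nc2ccc(C)cc2)cc(OC)c1OC` differs from compound 3 in a single group, with methyl in place of chloro on an aromatic carbon, para to a large group (methyl in place of chloro on an aromatic carbon). Among the compounds with values here, no measured pair makes this exact exchange, so the evidence is indirect. Fluoro in place of hydrogen on an aromatic carbon gave no change at the digits printed from compound 1 to compound 2 (within the scatter). Replacing a whole group gave a 1.9-fold lower number from compound 1 to compound 3 (0.28 log units; within the scatter) and a 1.9-fold lower number from compound 2 to compound 3 (0.28 log units; within the scatter). All three steps lie within the scatter, and none of them speaks for a direction in the present exchange. On these three steps, no change beyond the scatter is expected in this assay.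

The estimated step is a 1.1-fold higher number from compound 3 to compound 4 (0.04 log units; within the scatter). For compound 4 the expected value is 1200 nM, with an estimated range from 550 nM to 2600 nM.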

Compound 4, half-maximal inhibitory concentration: 1600 nM
Beside the measured number, compound 4's estimate is 1.3-fold (0.12 log units) below it; low and high end bracket the measured number.
By their numbers in this assay, from the lowest: compounds 3, 4, 1 and 2 (each within the scatter of the next).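

In this assay, within the data shown here, the exchange of chloro for methyl, on an aromatic carbon para to a large group, gave a 1.5-fold higher number from compound 3 to compound 4 (0.16 log units; within the scatter), the first direct reading of this change, and the position takes either group without a shift beyond the scatter. The (4-methylphenyl)amino group also fails to separate itself from the aryl groups held directly on the shared core: the comparison with the fluorinated compound gives a 1.3-fold lower number from compound 2 to compound 4 (0.12 log units; within the scatter), and the comparison with the unsubstituted one gives a 1.3-fold lower number from compound 1 to compound 4 (0.12 log units; within the scatter), so the four compounds cannot be put in any order here. Nothing measured on these compounds offers an explanation for how little either exchange moves the number.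

With only chloro and methyl shown on the (phenyl)amino ring at this position, it remains open whether a different kind of group there, such as a methoxy, an amine or a carboxylic acid, would carry the number beyond the scatter. Also open, from the compounds shown here alone, is whether the same exchange would read alike with an ether oxygen or a methylene in place of the amino nitrogen, and whether it would hold on any other cell line.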